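The compounds below may be only part of what the source reports. "The series", "measured", "known", "first", "only" and "open" are said of these compounds alone.

Of the compounds shown here, three sharing one core have been tested in a functional assay on HT-29 cells (Homo sapiens) for antiproliferative activity, read by sulforhodamine B assay, with a stated time of 48 h; on this read-out lower numbers stand for stronger inhibition and higher numbers for weaker inhibition. Compound 1 `CCCN1CCN(c2ccc(S(=O)(=O)Oc3ccccc3CC)cc2)C1=O` gives only a limit of the assay, > 100000 nM. Compound 2 `CCCN1CCN(c2ccc(S(=O)(=O)Oc3ccccc3OC)cc2)C1=O` also gives only a limit, > 100000 nM. Within the data shown here, compound 3 `CCCN1CCN(c2ccc(S(=O)(=O)Oc3cccc(C)c3)cc2)C1=O` gives 65000 nM, the only actual number so far.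

Compound 4 `CCCN1CCN(c2ccc(S(=O)(=O)Oc3cccc(OC)c3)cc2)C1=O` has not yet been measured. It differs from compound 3 by one small change, methoxy in place of methyl on an aromatic carbon, meta to a large group: methoxy in place of methyl on an aromatic carbon.

The measured steps offer limited guidance. The closest exchange of groups, methoxy in place of ethyl, gives a step that the two limits leave unreadable from compound 1 to compound 2. The two changes that lead to the 3-methylphenyl group give an at least 1.5-fold lower number from compound 1 to compound 3 (0.18 log units; that floor lies within the scatter) and an at least 1.5-fold lower number from compound 2 to compound 3 (0.18 log units; that floor lies within the scatter). None of these shows a step clearly beyond the scatter, so no clear change is expected here, and compound 4 could also reach the assay limit.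

The expected change is a 1.1-fold higher number from compound 3 to compound 4 (0.03 log units; within the scatter), which would stay within the scatter.

For compound 4, the estimated value is 70000 nM, with an expected range from 30000 nM to 100000 nM.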

Compound 4, half-maximal inhibitory concentration: 25000 nM
The estimate for compound 4 lay 2.8-fold (0.45 log units) above the measured number; the measured number lies below the stated range.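

In this assay, among these compounds, methoxy in place of methyl on an aromatic carbon, meta to a large group, gives a 2.6-fold lower number from compound 3 to compound 4 (0.41 log units; beyond the scatter), the first step in this set with a readable size beyond the scatter. With the methoxy group kept, 3-methoxyphenyl in place of 2-methoxyphenyl gives an at least 4.0-fold lower number from compound 2 to compound 4 (0.60 log units; beyond the scatter), so where the group sits on this ring clearly matters, and 3-methoxyphenyl in place of 2-ethylphenyl gives an at least 4.0-fold lower number from compound 1 to compound 4 (0.60 log units; beyond the scatter). Both of these steps are floors, and the true steps could be larger, because compound 1 and compound 2 each give only a limit: the limit of > 100000 nM in this assay, at which 2 of the 4 values shown sit.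

On these data alone, only methyl and methoxy can be compared directly at this position, so it remains open how a hydroxyl, an amine or a longer ethoxy chain would behave there. As far as these compounds go, it is also open whether a 3-chlorophenyl group would follow the same direction.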